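Swapping the thiophen-3-yl group of compound 3

The source may hold more compounds than are shown below. What is called first, only, known or untested is meant among the compounds shown, and "the series" means these compounds.

Results so far in a functional assay on EBC-1 cells (Homo sapiens) for antiproliferative activity, with a stated time of 72 h; a lower number here means a stronger inhibitor, a higher number a weaker inhibitor:
- Compound 1 `Cn1cc(-c2cc(C(F)(F)F)c3ncc(Cc4ccc5ncccc5c4)n3c2)cn1`: "not determined" (no result reported)
- Compound 2 `Cn1cc(-c2cc(C#N)c3ncc(Cc4ccc5ncccc5c4)n3c2)cn1`: "not determined" (no result reported)
- Compound 3 `Fc1cc(-c2ccsc2)cn2c(Cc3ccc4ncccc4c3)cnc12`: 444 nM

For the measured compounds named here, compound 3 holds the only actual number here, so it cannot yet be ranked against anything. The next compound, compound 4 `COc1ccc(-c2cc(F)c3ncc(Cc4ccc5ncccc5c4)n3c2)cc1F`, has 3-fluoro-4-methoxyphenyl in place of thiophen-3-yl on an aromatic carbon. Going by the values given here, no pair of measured compounds shows what a swap at this carbon does, so the forecast is uncertain. A modest loss of strength is expected, the estimated change being a 1.4-fold higher number from compound 3 to compound 4 (0.13 log units; within the scatter). For compound 4 the estimated value is 600 nM, with an expected range of 130 nM to 2800 nM.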

Compound 4, half-maximal inhibitory concentration: 407 nM
Estimate against measurement, compound 4: 1.5-fold (0.17 log units) above; the range from low to high includes it.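

In this assay, this aromatic carbon shows its first measured swap, a 1.1-fold lower number from compound 3 to compound 4 (0.04 log units; within the scatter) and so the two groups cannot be told apart. At this carbon, 3-fluoro-4-methoxyphenyl with 9 heavy atoms therefore gives the same reading as thiophen-3-yl with 5 heavy atoms, within the scatter. No supporting measurement bears on why these two groups match. Still open, from the compounds shown here alone, is whether a group without an aromatic ring at this carbon, such as an amine or a morpholine, would give a similar reading.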